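The source may hold more compounds than are shown below. What is called first, only, known or untested is meant among the compounds shown, and "the series" means these compounds.

Compound 1 `CC(Sc1nc2c(cnn2C)c(=O)n1-c1ccccc1)c1cccc(F)c1` — 151 nM
Compound 2 `Cn1ncc2c(=O)n(-c3ccccc3)c(OCc3cccc(F)c3)nc21` — 775 nM
Compound 3 `CC(Sc1nc2nn(CC3COC3)cc2c(=O)n1-c1ccccc1)c1ccccc1` — 100 nM

In an assay on isolated protein for inhibition of aldehyde dehydrogenase 1A1 (Homo sapiens) (a lower number here means a stronger inhibitor, a higher number a weaker inhibitor), compound 1 gives 151 nM, the second highest of the three numbers. Its nearest neighbour is compound 3 with 100 nM, a gap that lies within the scatter, so the two cannot be told apart. Furthest away is compound 2, which gives 775 nM; that gap lies beyond the scatter, so compound 1 is the stronger inhibitor of the two.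

The step to compound 4 `CC(Sc1nc2c(cnn2C)c(=O)n1-c1ccccc1)c1cncnc1` keeps the core of compound 1 and changes only the group on the saturated chain carbon bound to a saturated chain carbon and a sulfur: pyrimidin-5-yl in place of 3-fluorophenyl on a saturated chain carbon bound to a saturated chain carbon and a sulfur. Among the compounds with values here, no step between measured compounds in this assay shows what such an exchange does, so the expectation rests on the values shown alone. Because compound 1 gives 151 nM and compound 3 gives 100 nM with differing groups at the other end of the core, the core appears to tolerate variation, and a modest step toward a higher number is expected a 2.1-fold higher number from compound 1 to compound 4 (0.33 log units; beyond the scatter), close to the edge of the scatter. Compound 4 is therefore estimated at 320 nM, with a range from 110 nM to 950 nM.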

Compound 4, half-maximal inhibitory concentration: 94 nM
For compound 4 the middle estimate is 3.4-fold (0.53 log units) above the measured one; the measured number lies below the stated range.
By their numbers in this assay, from the lowest: compounds 4, 3 and 1 (each within the scatter of the next); then compound 2.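

In this assay, putting pyrimidin-5-yl in place of 3-fluorophenyl on a saturated chain carbon bound to a saturated chain carbon and a sulfur gives a 1.6-fold lower number from compound 1 to compound 4 (0.21 log units; within the scatter), the only step shown in which a single place on the core of compound 1 is changed. It shows that this place accepts a six-membered aromatic ring with 2 hetero atoms and 2 hydrogen-bond acceptors in place of a ring of carbon only bearing fluorine, with no difference that can be told apart from the usual scatter of repeated measurements. No measurement available here bears on why the two compounds cannot be told apart.

From the compounds shown here alone, this single exchange cannot show how far that tolerance reaches, and it remains open what a group of a different kind at this place, such as a piperidine ring, an amine or a carboxylic acid, would do to the number. It also leaves open whether pyrimidin-5-yl would give a similar result with a longer chain in place of the methyl group on the core.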